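Chloro to Methoxy on the Aryl Ring of Compound 2

This account rests on a few compounds, and the source may have more. Where it says the series, first, only, none or still open, it means among the compounds named here.

Compound 1 `COc1ccc(Cn2cc(CNC(=O)c3cn(-c4ccccc4)nc3-c3ccc(Cl)cc3)nn2)cc1OC`: 9400 nM
Compound 2 `COc1cc(Cn2cc(CNC(=O)c3cn(-c4ccccc4)nc3-c3ccc(Cl)cc3)nn2)cc(OC)c1`: 340 nM

Within the data shown here, in a functional assay on MIA PaCa-2 cells (Homo sapiens) for antiproliferative activity, read by sulforhodamine B assay, with a stated time of 48 h (on this read-out higher numbers stand for weaker inhibition of growth and lower numbers for stronger inhibition of growth), compound 2 stands at the lowest of the two numbers; its only neighbour is compound 1, and the step of a 28-fold lower number from compound 1 to compound 2 (1.44 log units; beyond the scatter) separates the two. Compound 3 `COc1ccc(-c2nn(-c3ccccc3)cc2C(=O)NCc2cn(Cc3cc(OC)cc(OC)c3)nn2)cc1` differs from compound 2 in one place: methoxy in place of chloro on an aromatic carbon. Among the measured compounds shown here, no measured step bears on this change; the single step on record, from compound 1 to compound 2, concerns the dimethoxyphenyl group on the saturated chain carbon, not the ring that carries the chloro. There is therefore no basis in the data for a step of any size or direction, and a result within the scatter of the number for compound 2 is expected. Compound 3 is estimated at 500 nM (range 150 nM to 2000 nM), which means an expected step of a 1.5-fold higher number from compound 2 to compound 3 (0.17 log units; within the scatter).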

Compound 3, concentration for 50% growth inhibition: 5800 nM
Compound 3: the middle estimate sits 12-fold (1.06 log units) below what was measured, and the stated range ends below it.
By their numbers in this assay, from the lowest: compound 2; then compounds 3 and 1 (each within the scatter of the next).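

The aryl ring on the other side of the core from the dimethoxyphenyl group proves just as sensitive: in this assay the change from 4-chlorophenyl to 4-methoxyphenyl gives a 17-fold higher number from compound 2 to compound 3 (1.23 log units; beyond the scatter) on a swap of a single substituent. The earlier pair showed a large step only for the placement of the methoxy groups on the dimethoxyphenyl ring, as a 28-fold lower number from compound 1 to compound 2 (1.44 log units; beyond the scatter) records, so compound 3 adds a second place where one change moves the number well beyond the scatter. Nothing at hand explains why this change has so large an effect. The compounds shown leave open how fluoro, methyl or an amine in place of chloro on this aromatic carbon would fare. They also leave open whether the step holds when the chain carries 3,4-dimethoxyphenyl instead.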